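Cyclohexyl to 4-(trifluoromethyl)phenyl on the amine nitrogen

A few compounds are considered here, and "the series" means these few. Any claim that something is new, unique, unknown or untested is made for them only; others in the source may bear on it.

Compound 3 `O=C1C=C(NC2CCCCC2)C(=O)c2c1nc1n2[C@H]2OC[C@@H](O)[C@H]2OC1` gives only a limit of > 16000 nM in a functional assay on HeLa cells (Homo sapiens) for inhibition, read by sulforhodamine B assay (on this read-out higher numbers stand for weaker inhibition and lower numbers for stronger inhibition), and no number.

Compound 1 `O=C1C(Nc2ccccc2F)=CC(=O)c2c1nc1n2[C@H]2OC[C@@H](O)[C@H]2OC1` gives 9820 nM in this assay and compound 2 `Cc1ccc(NC2=CC(=O)c3c(nc4n3[C@H]3OC[C@@H](O)[C@H]3OC4)C2=O)cc1` gives 6590 nM on the same read-out.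

Compound 4 `O=C1C=C(Nc2ccc(C(F)(F)F)cc2)C(=O)c2c1nc1n2[C@H]2OC[C@@H](O)[C@H]2OC1` has 4-(trifluoromethyl)phenyl in place of cyclohexyl on an amine nitrogen and so resembles compound 1 and compound 2 in carrying a substituted phenyl there.

Going by the values given here, the one measured step that bears on this is a 1.5-fold lower number from compound 1 to compound 2 (0.17 log units; within the scatter) and it shows no change in the phenyl substituent's effect beyond the scatter.

A move toward a lower number is therefore expected, with an at least 2.0-fold lower number from compound 3 to compound 4 (0.30 log units; that floor lies within the scatter) as the estimated step against a limit.

The estimate for compound 4 is 8000 nM with an expected range of 3500 nM to 16000 nM in this assay for now.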

Compound 4, half-maximal inhibitory concentration: > 8000 nM
Compound 4 was reported as a limit (the forecaster's own chance of this, stated with the estimate: 20%); the middle value sits exactly at the limit.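

Going by these compounds alone, compound 3 and compound 4 are both reported only as limits in this assay, so no step between them can be read. The compounds shown leave open whether cyclohexyl or 4-(trifluoromethyl)phenyl on the amine nitrogen gives the lower number.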